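The source may report more compounds than this note shows. Statements on the series, on what has been measured and on what is new or still open speak of the compounds shown alone.

Compound 3 `O=C(NCc1cc(Cl)ccc1-n1cnnn1)[C@@H]1[C@@H]2C[C@@H]2CN1C(=O)[C@H](O)c1ccccc1F` is the starting point. In a functional assay on a cell-free system (plasma, Homo sapiens), with a stated time of 3 min (a lower number here means a stronger inhibitor, a higher number a weaker inhibitor), compound 3 gives 580 nM, the favourable end of the three numbers; compound 1 `O=C(NCc1cc(Cl)ccc1-n1cnnn1)[C@@H]1[C@@H]2C[C@@H]2CN1C(=O)[C@H](O)c1ccccc1` with 700 nM sits within the scatter of it, as a 1.2-fold lower number from compound 1 to compound 3 (0.08 log units; within the scatter) shows, while compound 2 `O=C(NCc1cc(Cl)ccc1-n1cnnn1)[C@@H]1[C@@H]2C[C@@H]2CN1C(=O)[C@H](O)Cc1ccccn1` with 1700 nM lies further off, a 2.9-fold lower number from compound 2 to compound 3 (0.47 log units; beyond the scatter). Compound 4 `CC(C)(C)[C@@H](O)C(=O)N1C[C@H]2C[C@H]2[C@H]1C(=O)NCc1cc(Cl)ccc1-n1cnnn1` carries the change (tert-butyl in place of 2-fluorophenyl on a saturated chain carbon bound to a carbonyl carbon and an oxygen on a saturated carbon). Among the compounds with values here, no measured step swaps the aromatic ring for a branched chain; the closest guide is a 2.4-fold higher number from compound 1 to compound 2 (0.39 log units; beyond the scatter), a modest loss when phenyl gave way to a non-aromatic attachment. A modest weakening is therefore expected, a 2.2-fold higher number from compound 3 to compound 4 (0.35 log units; beyond the scatter), with compound 4 estimated at 1300 nM in this assay, ranging from 450 nM to 3800 nM.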

Compound 4, half-maximal inhibitory concentration: 1200 nM
Estimate against measurement, compound 4: 1.1-fold (0.03 log units) above; the range from low to high includes it.
By their numbers in this assay, from the lowest: compounds 3, 1, 4 and 2 (each within the scatter of the next, the first and the last beyond it).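

In this assay, an aromatic ring on this carbon is not needed for inhibition: tert-butyl, which has no ring, gives only a modest loss against 2-fluorophenyl (a 2.1-fold higher number from compound 3 to compound 4 (0.32 log units; beyond the scatter)). The same tert-butyl group stays within the scatter of both phenyl (a 1.7-fold higher number from compound 1 to compound 4 (0.23 log units; within the scatter)) and (pyridin-2-yl)methyl (a 1.4-fold lower number from compound 2 to compound 4 (0.15 log units; within the scatter)). Nothing measured here explains these steps. The compounds shown leave open how cyclohexyl, a saturated ring, would compare with tert-butyl at this position. They also leave open whether a chain ending in an amine or a carboxylic acid would be tolerated.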